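The source may hold more compounds than are shown below. What is called first, only, known or untested is meant among the compounds shown, and "the series" means these compounds.

In an assay on cells for displacement of a labelled ligand from 5-hydroxytryptamine receptor 7 (Homo sapiens), read by scintillation counting, with a stated time of 30 min (a lower number here means a stronger inhibitor, a higher number a weaker inhibitor), two compounds have been measured so far:
compound 1 `O=C(CCN1CCN(c2ccc(Cl)cc2)CC1)N1CCN(c2ccccc2)CC1` gives 462 nM
compound 2 `CCOc1ccccc1N1CCN(CCC(=O)N2CCN(c3ccccc3)CC2)CC1` gives 80.3 nM

Compound 1 stands with the higher number of the two, and the step of a 5.8-fold lower number from compound 1 to compound 2 (0.76 log units; beyond the scatter) lies beyond the scatter. That step came from swapping the aryl group on the amine nitrogen in the ring, 2-ethoxyphenyl in place of 4-chlorophenyl. Compound 3 `O=C(CCN1CCN(c2ccc(Cl)cc2)CC1)N1CCN(c2cccc(Cl)c2)CC1` has not yet been measured. It differs from compound 1 in another place: chloro in place of hydrogen on an aromatic carbon, on the ring that compound 1 and compound 2 carry unchanged. Within the data shown here, no measured step touches that ring, so the single step in hand gives no guide to either direction or size. Relative to compound 1, the expected step for compound 3 is a 1.3-fold lower number from compound 1 to compound 3 (0.12 log units; within the scatter), which need not reach beyond the scatter. The estimate for compound 3 in this assay is 350 nM, within a range from 120 nM to 1000 nM.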

Compound 3, inhibition constant: 2370 nM
Compound 3: middle estimate off by 6.8-fold (0.83 log units), on the low side, outside the stated range (above it).
By their numbers in this assay, from the lowest: compound 2; then compound 1; then compound 3.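

Going from phenyl to 3-chlorophenyl adds a single heavy atom, yet in this assay it gives a 5.1-fold higher number from compound 1 to compound 3 (0.71 log units; beyond the scatter), so this ring, untouched by the earlier step, also affects the result. At this one place, meta to a large group, the chloro makes the inhibitor weaker rather than leaving it unchanged or making it stronger. Nothing measured here explains how the added chlorine produces this effect.

Still open, going by these compounds, is whether this loss belongs to chloro specifically or would follow any added group here, which a fluoro, methyl or methoxy group at the same place could help separate. Also open is how the 3-chlorophenyl would behave alongside the 2-ethoxyphenyl, a pairing found in none of the compounds shown.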